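Stretching the chain further beyond the measured pair

The source may hold more compounds than are shown below. What is called first, only, known or untested is meant among the compounds shown, and "the series" means these compounds.

Of the compounds shown here, two have been measured in an assay on cells for inhibition of protein deacetylase HDAC6 (Homo sapiens), in the presence of a further agent that is not named here; a higher number here means a weaker inhibitor, a lower number a stronger inhibitor. Compound 1 `O=C(CCCn1cc(-c2ncnc3[nH]ccc23)cn1)NO` gives 604 nM, while compound 2 `O=C(CCCCCCCn1cc(-c2ncnc3[nH]ccc23)cn1)NO` gives 1.8 nM. Among the compounds with values here, compound 2 thus holds the lowest number of the two, and the only step measured so far, a 340-fold lower number from compound 1 to compound 2 (2.53 log units; beyond the scatter), runs in its favour: lengthening the chain between the aromatic nitrogen and the hydroxamic acid by four carbons brought a very large gain.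

Compound 3 `O=C(CCCCCCCCCCn1cc(-c2ncnc3[nH]ccc23)cn1)NO` pushes the same idea further. Relative to compound 2 the change is 3-(hydroxycarbamoyl)propyl in place of hydroxycarbamoyl on a saturated chain carbon, seven bonds along the chain from an aromatic nitrogen, so the chain grows by another three carbons. Within the data shown here, the one step that bears on this, from compound 1 to compound 2, was large, but it started from a short chain, and nothing measured here tells whether a chain that is already long still gains from further extension or begins to lose. Among the measured compounds shown here, with only that single step as a guide, the expectation for compound 3 is a modest change, most likely a small rise in the number toward a slightly weaker inhibitor, a 2.2-fold higher number from compound 2 to compound 3 (0.35 log units; beyond the scatter), that may stay within the scatter. Compound 3 is therefore estimated at 4 nM, within a range of 1.2 nM to 15 nM.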

Compound 3, half-maximal inhibitory concentration: 88 nM
The estimate for compound 3 lay 22-fold (1.34 log units) below the measured number, outside the stated range (above it).
By their numbers in this assay, from the lowest: compound 2; then compound 3; then compound 1.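

With compound 3, the position on the saturated chain, seven bonds along from an aromatic nitrogen, turns out not to reward extension without limit: in this assay, 3-(hydroxycarbamoyl)propyl in place of hydroxycarbamoyl gives a 49-fold higher number from compound 2 to compound 3 (1.69 log units; beyond the scatter), reversing much of the gain seen in the earlier step. Chain length therefore acts in both directions across this short series, with compound 2 holding the lowest number and both the shorter chain of compound 1 and the longer chain of compound 3 giving clearly higher ones, although of these two compound 3 still holds the lower number, with compound 3 at 88 nM and compound 1 at 604 nM. Nothing available accounts for this reversal in terms of how the longer chain acts.

The three compounds leave open where the best length lies, since chains shorter than that of compound 3 but longer than that of compound 1 could match or improve on compound 2, apart from the one length tested. They also leave open whether a carboxylic acid or an amine at the chain end, in place of hydroxycarbamoyl, would follow the same dependence on length.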